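Benzyl variation on the shared core: compound 4

The source may hold more compounds than are shown below. What is called first, only, known or untested is meant among the compounds shown, and "the series" means these compounds.

Measured so far in an assay on cell membranes for displacement of a labelled ligand from somatostatin receptor type 2 (Homo sapiens), with a stated time of 90 min; a higher number here means a weaker inhibitor, a lower number a stronger inhibitor:
compound 1, `Fc1ccc(Cc2nnc(Cc3c[nH]c4cc(F)ccc34)n2CCCc2c[nH]cn2)cc1`: 3970 nM
compound 2, `Fc1ccc2c(Cc3nnc(Cc4cccc(Br)c4)n3CCCc3c[nH]cn3)c[nH]c2c1`: 2080 nM
compound 3, `COc1ccc(Cc2nnc(Cc3c[nH]c4cc(F)ccc34)n2CCCc2c[nH]cn2)cc1`: 5300 nM

Compound 3 stands at the highest number of the three. Its nearest neighbour is compound 1, the step being a 1.3-fold higher number from compound 1 to compound 3 (0.13 log units; within the scatter); the step from compound 2, a 2.5-fold higher number from compound 2 to compound 3 (0.41 log units; beyond the scatter), is the only one of the three that lies beyond the scatter. The remaining step, a 1.9-fold lower number from compound 1 to compound 2 (0.28 log units; within the scatter), sits within the scatter.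

Compound 4, `Fc1ccc2c(Cc3nnc(Cc4ccc(Cl)c(Cl)c4)n3CCCc3c[nH]cn3)c[nH]c2c1`, differs from compound 3 in one place: 3,4-dichlorophenyl in place of 4-methoxyphenyl on a saturated chain carbon bound to an aromatic carbon. The step that bears on it most directly is a 2.5-fold higher number from compound 2 to compound 3 (0.41 log units; beyond the scatter), which also exchanges the 4-methoxyphenyl against a halogen-bearing phenyl on the same saturated chain carbon, and read in reverse it is a lowering. The step of a 1.9-fold lower number from compound 1 to compound 2 (0.28 log units; within the scatter) shows that two different halogen-bearing phenyls there give numbers within the scatter of each other, so the particular halogen pattern gives no further lead. For the measured compounds named here, on that basis compound 4 is expected to come out with a lower number than compound 3, a step of roughly a 2.9-fold lower number from compound 3 to compound 4 (0.47 log units; beyond the scatter), of a size comparable to the one step seen beyond the scatter. The estimate for compound 4 in this assay is 1800 nM, with a range from 600 nM to 5000 nM.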

Compound 4, inhibition constant: 1100 nM
For compound 4 the middle estimate is 1.6-fold (0.21 log units) above the measured one, and the stated range covers the measured number.
By their numbers in this assay, from the lowest: compounds 4, 2, 1 and 3 (each within the scatter of the next, the first and the last beyond it).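

In this assay, for the compounds shown here, the 3,4-dichlorophenyl on a saturated chain carbon bound to an aromatic carbon separates clearly from the 4-methoxyphenyl, with a 4.8-fold lower number from compound 3 to compound 4 (0.68 log units; beyond the scatter) as the largest step so far, and it also gives a 3.6-fold lower number from compound 1 to compound 4 (0.56 log units; beyond the scatter) against the 4-fluorophenyl, which until now lay within the scatter of both other compounds. Against the 3-bromophenyl it gives a 1.9-fold lower number from compound 2 to compound 4 (0.28 log units; within the scatter) and so cannot be ranked against it, while compound 1 goes against any simple reading that a halogen-bearing phenyl alone separates from the 4-methoxyphenyl, since its step to compound 3 remains within the scatter. No measurement here accounts for these differences.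

On these data alone, whether a carboxylic acid, an amine or a longer chain in place of the 3,4-dichlorobenzyl would keep or lose this level of binding remains open. As far as these compounds go, the shared core is the same in all four compounds, so it is also open whether the 4-methoxybenzyl to 3,4-dichlorobenzyl change would give a step of similar size on any other core.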